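Working notes: from compound 3 to compound 4

This account rests on a few compounds, and the source may have more. Where it says the series, first, only, none or still open, it means among the compounds named here.

In a functional assay on MCF7 cells (Homo sapiens) for antiproliferative activity, read by MTT assay, with a stated time of 72 h (on this read-out lower numbers stand for stronger inhibition and higher numbers for weaker inhibition), compound 1 `CCCSc1nc(N/N=C/c2ccc(N(C)C)cc2)c2nnn(Cc3ccccc3)c2n1` gives 12200 nM as its reading. Compound 2 `CCCSc1nc(N/N=C/c2ccc(Br)cc2)c2nnn(Cc3ccccc3)c2n1` reads > 64000 nM as a limit of the assay and not a number. Compound 3 `CCCSc1nc(N/N=C(\C)c2ccccc2)c2nnn(Cc3ccccc3)c2n1` gives 32100 nM as the higher of the two actual numbers, the other belonging to compound 1. Among the compounds with values here, the change to compound 4 `CCCSc1nc(N/N=C/c2ccccc2)c2nnn(Cc3ccccc3)c2n1` is a group of 8 heavy atoms (7 carbon, 1 nitrogen; one six-membered aromatic ring of carbon only) in place of a group of 9 heavy atoms (8 carbon, 1 nitrogen; one six-membered aromatic ring of carbon only), on a nitrogen on an aromatic ring on a nitrogen on an aromatic ring, and no measured step isolates it. Within the data shown here, two steps bear on it only indirectly. The first, an at least 5.2-fold higher number from compound 1 to compound 2 (0.71 log units; beyond the scatter), shows that the read-out responds to a substituent change on the aromatic carbon. The second, an at least 1.9-fold lower number from compound 2 to compound 3 (0.29 log units; that floor lies within the scatter), has a floor within the scatter. Neither step gives a size or direction for this change, so no step beyond the scatter is expected in this assay here. The expected size is a 1.1-fold lower number from compound 3 to compound 4 (0.03 log units; within the scatter) by this estimate. The estimated value for compound 4 is 30000 nM with an expected range from 13000 nM to 64000 nM in this assay.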

Compound 4, half-maximal inhibitory concentration: > 64000 nM
Compound 4 was reported as a limit; the forecaster's own chance of this, stated with the estimate: 20%; middle value at least 2.1-fold (0.32 log units) away from the limit.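

In this assay compound 4 reads > 64000 nM, a limit of the assay and not a number. The change of group on a nitrogen on an aromatic ring gives an at least 1.9-fold higher number from compound 3 to compound 4 (0.29 log units; that floor lies within the scatter), so the step has a measured direction, but its floor does not establish a change beyond the scatter. Removing the dimethylamino group gives an at least 5.2-fold higher number from compound 1 to compound 4 (0.71 log units; beyond the scatter), which is beyond the scatter and shows that the unsubstituted aromatic ring gives up the reading held by compound 1.

The step between compound 2 and compound 4 cannot be read, and hydrogen and bromo remain unordered: the limit of > 64000 nM in this assay, at which 2 of the 4 values shown sit. On these data alone, it remains open whether a smaller amine such as methylamino, or a carboxylic acid, put where the dimethylamino group stands would give a reading inside the limit.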